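The source may hold more compounds than are shown below. What is called first, only, known or untested is meant among the compounds shown, and "the series" means these compounds.

In an ADME assay on HEL cells (Homo sapiens) for cytotoxicity (a higher number here means that more compound is tolerated, a lower number that less compound is tolerated), compound 1 `O=C(COc1cccc2ccccc12)N/N=C/c1ccc(Cl)cc1` gives 100 ug/mL and compound 2 `O=C(COc1cccc2ccccc12)N/N=C/c1ccccc1Br` gives 100 ug/mL. Between these two, with a bromo group in compound 2 and a chloro group in compound 1, the measurement shows no change at the digits printed from compound 1 to compound 2 (within the scatter). Compound 3 `O=C(COc1cccc2ccccc12)N/N=C/c1ccccc1O`, which carries a hydroxy group, has the lowest number of the three at 3.57 ug/mL, so cells tolerate less of it. The gap to the others is wide: a 28-fold lower number from compound 1 to compound 3 (1.45 log units; beyond the scatter), and likewise a 28-fold lower number from compound 2 to compound 3 (1.45 log units; beyond the scatter).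

The next compound is compound 4 `O=C(COc1cccc2ccccc12)N/N=C/c1ccccc1`, which differs from compound 3 in one place: hydrogen in place of hydroxy on an aromatic carbon. In other words, hydrogen replaces hydroxy on an aromatic carbon, turning 2-hydroxyphenyl into phenyl.

Within the data shown here, no measured compound has this plain phenyl group, so the evidence is indirect. Only compound 3 has the hydroxy group, and the two compounds without it, compound 1 at 100 ug/mL and compound 2 at 100 ug/mL, share the same number. Three compounds are a thin basis, but they suggest that removing the hydroxy group should bring compound 4 up towards that pair. The expected change is a large rise, a 20-fold higher number from compound 3 to compound 4 (1.29 log units; beyond the scatter). Compound 4 is estimated at 70 ug/mL, with an expected range of 20 ug/mL to 110 ug/mL.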

Compound 4, half-maximal cytotoxic concentration: 64.5 ug/mL
The estimate for compound 4 lay 1.1-fold (0.04 log units) above the measured number, and the stated range covers the measured number.
By their numbers in this assay, from the lowest: compound 3; then compounds 4, 1 and 2 (each within the scatter of the next).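

In this assay, the hydroxy group can now be judged by a direct swap at a single place: putting hydrogen on that aromatic carbon gives an 18-fold higher number from compound 3 to compound 4 (1.26 log units; beyond the scatter) and so turns 2-hydroxyphenyl into phenyl. The low number of compound 3 therefore goes with the hydroxy group itself and not with the shared core, which on its own, carrying a plain phenyl, is well tolerated by the cells. The comparisons with the halogen compounds add that neither halogen stands apart from hydrogen, with a 1.6-fold lower number from compound 2 to compound 4 (0.19 log units; within the scatter) for bromo and a 1.6-fold lower number from compound 1 to compound 4 (0.19 log units; within the scatter) for chloro, which leaves the hydroxy group as the only substituent in this set tied to a large change, though nothing measured here says why it has this effect.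

The compounds shown leave open whether a low number belongs to the hydroxy group alone or would also come with a methoxy or an amino group at this place. They also leave open whether a hydroxy group on another carbon of the same ring would go with a low number too.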